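The compounds below may be only part of what the source reports. "The series", "measured", "known", "first", "only" and "open" are said of these compounds alone.

Measured in a functional assay on cells (Homo sapiens) for cytotoxicity, read by MTT assay, with a stated time of 24 h; on this read-out lower numbers stand for stronger inhibition and higher numbers for weaker inhibition:
- compound 1 `CCCCCCCCCCCCCCNC(=O)[C@H](CO)/N=C/c1ccccc1[N+](=O)[O-]`: 21700 nM
- compound 2 `CCCCCCCCCCCCCCNC(=O)[C@H](CO)/N=C/c1ccc(Cl)cc1`: 27500 nM
- compound 3 `CCCCCCCCCCCCCCNC(=O)[C@H](CO)/N=C/c1ccccc1`: 7670 nM

Of these three, compound 3 gives the lowest number, 7670 nM, and so is the most potent in this assay. The next structure, compound 4 `CCCCCCCCCCCCCCNC(=O)[C@H](CO)/N=C/c1ccc(C)cc1`, keeps the shared core and differs from compound 3 in one place: methyl in place of hydrogen on an aromatic carbon, which turns phenyl into 4-methylphenyl (methyl in place of hydrogen on an aromatic carbon).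

Within the data shown here, two measured steps bear on this change, and both remove a ring substituent. One is a 3.6-fold lower number from compound 2 to compound 3 (0.55 log units; beyond the scatter), where hydrogen replaces chloro, and the other is a 2.8-fold lower number from compound 1 to compound 3 (0.45 log units; beyond the scatter), where hydrogen replaces nitro. Both steps are modest and both end at a lower number, so adding a group to the ring of compound 3 is expected to raise the number in this assay. Among the measured compounds shown here, no compound with a methyl on the ring has been measured, so the size rests only on these two steps, and a somewhat smaller rise seems the fair expectation. The expected move is a 1.8-fold higher number from compound 3 to compound 4 (0.26 log units; within the scatter). For compound 4 the estimated value is 14000 nM, with an expected range from 6000 nM to 30000 nM.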

Compound 4, half-maximal inhibitory concentration: 102000 nM
Compound 4: the middle estimate sits 7.3-fold (0.86 log units) below what was measured, outside the stated range (above it).
By their numbers in this assay, from the lowest: compound 3; then compounds 1 and 2 (each within the scatter of the next); then compound 4.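

In this assay the ring carbon para to a large group proves far more sensitive than the chloro and nitro compounds suggested: adding a methyl, only 1 heavy atom, gives a 13-fold higher number from compound 3 to compound 4 (1.12 log units; beyond the scatter) and is the largest step seen so far. Methyl also differs clearly from the other ring substituents, with a 3.7-fold higher number from compound 2 to compound 4 (0.57 log units; beyond the scatter) when it takes the place of chloro and a 4.7-fold higher number from compound 1 to compound 4 (0.67 log units; beyond the scatter) when 4-methylphenyl takes the place of 2-nitrophenyl, so a ring substituent does not carry one fixed cost over the plain phenyl of compound 3. No supporting measurement accounts for such a large change from so small a group.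

The compounds shown leave open whether this sharp rise belongs to methyl alone or would also appear with an ethyl, a methoxy, an amine or a carboxylic acid at the same carbon. They also leave open whether any group on this ring can bring the number below that of the unsubstituted phenyl, which so far holds the lowest value.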